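Trimming the side chain from isopropyl to methyl

The compounds below may be only part of what the source reports. "The series", "measured", "known", "first", "only" and "open" are said of these compounds alone.

The series shares one core, varied only at the saturated chain carbon bound to an amide-type nitrogen and a carbonyl carbon. In a functional assay on the whole organism (Tail, strain ICR) with Mus musculus as the target, in the tail flick test, with a stated time of 120 min, at a dose of 25 umol/kg by the oral route (on this read-out higher numbers stand for a stronger effect at the one dose given and lower numbers for a weaker effect), compound 1 `O=C(O)CC[C@H](NC(=O)CN(c1nc(Cl)nc2[nH]cnc12)C1CC1)C(=O)O` gives 30.1%, while compound 2 `CC(C)[C@H](NC(=O)CN(c1nc(Cl)nc2[nH]cnc12)C1CC1)C(=O)O` gives 17.1%. Compound 2 therefore stands as the lower of the two numbers, the change being a number 13 percentage points lower from compound 1 to compound 2 (beyond the scatter).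

Compound 3 `C[C@H](NC(=O)CN(c1nc(Cl)nc2[nH]cnc12)C1CC1)C(=O)O` has not yet been measured. It differs from compound 2 in one place: methyl in place of isopropyl on a saturated chain carbon bound to an amide-type nitrogen and a carbonyl carbon.

Among the measured compounds shown here, only one measured step exists, the one from compound 1 to compound 2, and it concerns a different exchange at the same carbon. It shows that the group at this carbon can move the read-out by a modest amount, but it does not involve methyl and so gives no direction for the present change. Compound 3 is therefore expected to stay near compound 2, and the estimated step is a number 0.9 percentage points higher from compound 2 to compound 3 (within the scatter), not clearly beyond the scatter in either direction. The value of compound 3 is estimated at 18%, with a range from 6% to 32%.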

Compound 3, a percentage reported as activity, at one dose (the size of the read-out at that dose, not a potency): 28.4%
Compound 3: the middle estimate sits 10.4 percentage points below what was measured; measured number inside the range.
By their numbers in this assay, from the lowest: compound 2; then compounds 3 and 1 (each within the scatter of the next).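

Placed in this assay, the exchange of isopropyl for methyl gives a number 11.3 percentage points higher from compound 2 to compound 3 (beyond the scatter), so the lower number of compound 2 does not follow simply from the loss of the 2-carboxyethyl group at this carbon. The comparison with the original side chain gives a number 1.7 percentage points lower from compound 1 to compound 3 (within the scatter), which shows that the carboxylic acid at the end of that chain is not needed to reach this level of effect at the one dose given, and that among the three groups only isopropyl stands apart. Nothing available explains why isopropyl behaves differently from methyl and 2-carboxyethyl.

The compounds shown leave open whether a longer unbranched chain such as n-butyl, a branched chain such as isobutyl, or a chain ending in an amine at this carbon would group with compound 2 or with compounds 1 and 3. With one oral dose read at one time, they also leave open whether the similar read-outs of compounds 1 and 3 would hold at other doses or times.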